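A few compounds are considered here, and "the series" means these few. Any claim that something is new, unique, unknown or untested is made for them only; others in the source may bear on it.

Measured compounds in a functional assay on HeLa cells (Homo sapiens) for antiproliferative activity, with a stated time of 24 h; on this read-out lower numbers stand for stronger inhibition and higher numbers for weaker inhibition:
- compound 1 `NC(=O)c1c(NC(=O)c2ccccc2Br)sc2c1CCN(C(=S)Nc1ccccc1Cl)C2`: 46900 nM
- compound 2 `NC(=O)c1c(NC(=O)c2ccccc2C(F)(F)F)sc2c1CCN(C(=S)Nc1ccccc1Cl)C2`: 46900 nM
- compound 3 `Cc1ccccc1C(=O)Nc1sc2c(c1C(N)=O)CCN(C(=S)Nc1ccccc1Br)C2`: > 50000 nM, a limit of this assay, not a number

Compound 1 and compound 2 share one core and differ in one place, (trifluoromethyl in place of bromo on an aromatic carbon). The step of no change at the digits printed from compound 1 to compound 2 (within the scatter) sits within the scatter, so nothing separates the two values.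

Compound 3 carries a different core; the difference between the two cores from compound 1 to compound 3 is not broken down here. Compound 3 reports only a limit, (the limit of > 50000 nM in this assay, at which 1 of the 3 values shown sits).

Compound 4 `Cc1ccccc1C(=O)Nc1sc2c(c1C(N)=O)CCN(C(=S)Nc1ccccc1C(F)(F)F)C2` stands to compound 3 as compound 2 stands to compound 1: trifluoromethyl in place of bromo on an aromatic carbon. The place is the same in both pairs.

For compound 4 in this assay the expected step that the limit leaves unreadable from compound 3 to compound 4 is no more than the scatter, because the same change gave no change at the digits printed from compound 1 to compound 2 (within the scatter) and compound 3 already sits at the limit > 50000 nM. Compound 4 is therefore expected to give 60000 nM, most likely reported again only as a limit, with the estimate spanning 30000 nM to 150000 nM.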

Compound 4, half-maximal inhibitory concentration: > 50000 nM
Compound 4 ended at the assay's limit; the forecaster's own chance of this, stated with the estimate: 80%; the middle value does not contradict the limit.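

In this assay compound 4 gives > 50000 nM as a limit of the assay and not a number. Among the compounds shown here, compound 3 also reports only a limit, so no step from compound 3 to compound 4 can be read. Left open is how far each compound lies from that limit, and whether trifluoromethyl in place of bromo matters on this core.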